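Same Chain Change Applied to Two Cores

The source may report more compounds than this note shows. Statements on the series, on what has been measured and on what is new or still open speak of the compounds shown alone.

Compound 1, `COc1ccc(C2CC2C(=O)NNc2nncc3ccccc23)cc1`, gives 96000 nM in a functional assay on A549 cells (Homo sapiens) for inhibition, read by MTT assay, with a stated time of 72 h; on this read-out higher numbers stand for weaker inhibition and lower numbers for stronger inhibition.
Compound 2, `CC(C)=CCOc1ccc(C2CC2C(=O)NNc2nncc3ccccc23)cc1`, gives 82000 nM in this assay.
Compound 3, `COc1ccc(C2CC2C(=O)NNC(=O)c2ccncc2)cc1`, gives > 100000 nM in this assay, and this is a limit of the assay rather than a number.

The difference between compound 1 and compound 2 is 2-methylprop-1-en-1-yl in place of hydrogen on a saturated chain carbon bound to an oxygen on an aromatic ring. Measured in this assay, this change produced a 1.2-fold lower number from compound 1 to compound 2 (0.07 log units; within the scatter), so on the core of compound 1 the two compounds cannot be told apart.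

Compound 4, `CC(C)=CCOc1ccc(C2CC2C(=O)NNC(=O)c2ccncc2)cc1`, has not yet been measured. For the measured compounds named here, it differs from compound 3 by 2-methylprop-1-en-1-yl in place of hydrogen on a saturated chain carbon bound to an oxygen on an aromatic ring, the same change at the same place as the one between compound 1 and compound 2. The difference between the core of compound 1 and the core of compound 3 is not broken down here.

For compound 4 in this assay the account rests on two things. First, the same change on the core of compound 1 gave a 1.2-fold lower number from compound 1 to compound 2 (0.07 log units; within the scatter), a step too small to be seen. Second, compound 3 already stands at the limit of > 100000 nM in this assay, at which 1 of the 3 values shown sits, so a measurement of compound 4 is most likely to return only a limit again. Compound 4 is therefore expected to give about 120000 nM, between 60000 nM and 300000 nM. The step this estimate implies is a step that the limit leaves unreadable from compound 3 to compound 4, expected to stay within the scatter, because the limit of > 100000 nM in this assay, at which 1 of the 3 values shown sits, leaves little room for a measurable change.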

Compound 4, half-maximal inhibitory concentration: > 100000 nM
Compound 4 was reported as a limit; the forecaster's own chance of this, stated with the estimate: 70%; the middle value is on the limit's open side.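

In this assay, for the compounds shown here, compound 3 and compound 4 both come back only as limits of the assay, so no step from one to the other can be read. The compounds shown leave open whether 2-methylprop-1-en-1-yl in place of hydrogen has any effect on the core of compound 3, and whether that core can give a readable number in this assay at all.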